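Adding a third methoxy on the chlorovinyl aryl ring

The source may hold more compounds than are shown below. What is called first, only, known or untested is meant among the compounds shown, and "the series" means these compounds.

Measured so far:
compound 1, `COc1ccc2[nH]cc(C(=O)/C(C#N)=C/C=C(\Cl)c3ccc(OC)c(OC)c3)c2c1` — 34.2%
compound 2, `COc1ccc(/C(Cl)=C/C=C(\C#N)C(=O)c2c[nH]c3ccc(OC)cc23)cc1` — 16.7%

Both compounds were tested in a functional assay for inhibition, with a stated time of 30 min, tested at 1 mM; a lower number here means less inhibition, a higher number more inhibition at the concentration tested (going by the name of the read-out). Compound 1 gives the higher of the two numbers in this assay; compound 2 sits a step below it, a number 17.5 percentage points lower from compound 1 to compound 2 (beyond the scatter), a modest step that lies beyond the scatter. That step came from hydrogen in place of methoxy on an aromatic carbon.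

Compound 3, `COc1ccc2[nH]cc(C(=O)/C(C#N)=C/C=C(\Cl)c3cc(OC)c(OC)c(OC)c3)c2c1`, is not yet measured. It differs from compound 1 by methoxy in place of hydrogen on an aromatic carbon. Among the measured compounds shown here, the one measured step runs the opposite way, methoxy removed rather than added, and it lowered inhibition. On that basis an added methoxy is expected to leave inhibition in this assay unchanged or to raise it modestly. Compound 3 is expected to give about 42%, within 25% to 60%. The expected step is a number 7.8 percentage points higher from compound 1 to compound 3 (within the scatter).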

Compound 3, a percentage reported as inhibition, at one concentration (the size of the read-out at that concentration, not a potency): 46.1%
Compound 3: middle estimate off by 4.1 percentage points, on the low side, and the stated range covers the measured number.
By their numbers in this assay, from the lowest: compound 2; then compound 1; then compound 3.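

In this assay the methoxy entering ortho to a methoxy group gives a number 11.9 percentage points higher from compound 1 to compound 3 (beyond the scatter) and so shows that this ring takes a further methoxy, meta to a large group, with no loss of inhibition. Read with a number 17.5 percentage points lower from compound 1 to compound 2 (beyond the scatter) this gives two steps beyond the scatter in opposite directions: among these three compounds, inhibition rises with the number of methoxy groups on this ring, and none goes against that. Nothing available explains why the added methoxy goes with more inhibition.

On these data alone, whether the gain belongs to methoxy itself or would also come with a hydroxyl, a fluorine or an ethoxy group at this position stays open. Also open, as far as these compounds go, is whether the order holds at other concentrations, as this read-out is a percentage at one concentration and not a potency.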